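Replacing 2,4-difluorobenzyl with propyl: what compound 3 may show

The source may hold more compounds than are shown below. What is called first, only, known or untested is meant among the compounds shown, and "the series" means these compounds.

Compound 2 `C=C1C(=O)O[C@H]2[C@H]1CC/C(COC(=O)Cn1cc(F)c(=O)n(Cc3ccc(F)cc3F)c1=O)=C\CC[C@@]1(C)O[C@@H]21` sits at the weaker end of the two numbers in hand: in a functional assay on Bel7402/5-FU cells (Homo sapiens) for antiproliferative activity, read by MTT assay, with a stated time of 72 h (a higher number here means a weaker inhibitor, a lower number a stronger inhibitor), compound 2 gives 5010 nM, whereas compound 1 `C=C1C(=O)O[C@H]2[C@H]1CC/C(COC(=O)Cn1cc(F)c(=O)n(Cc3ccc(C(F)(F)F)cc3)c1=O)=C\CC[C@@]1(C)O[C@@H]21` gives 2250 nM. Among the compounds with values here, the only measured step is a 2.2-fold higher number from compound 1 to compound 2 (0.35 log units; beyond the scatter), an exchange of one six-membered aromatic ring for another on a saturated chain carbon bound to an aromatic nitrogen, which moved the number modestly.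

Compound 3 `C=C1C(=O)O[C@H]2[C@H]1CC/C(COC(=O)Cn1cc(F)c(=O)n(CCC)c1=O)=C\CC[C@@]1(C)O[C@@H]21` differs from compound 2 by ethyl in place of 2,4-difluorophenyl on a saturated chain carbon bound to an aromatic nitrogen. Within the data shown here, no measured step exchanges an aromatic ring for a short chain at a saturated chain carbon bound to an aromatic nitrogen, so the one step in hand bears on it only loosely: it shows that changing the group there shifts the number by a modest amount. With the ring removed outright, a further modest weakening is expected, though a number within the scatter of compound 2 cannot be excluded. Compound 3 is therefore expected to give 7000 nM in this assay, within 2500 nM to 20000 nM. The expected step is a 1.4-fold higher number from compound 2 to compound 3 (0.15 log units; within the scatter).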

Compound 3, half-maximal inhibitory concentration: 9110 nM
The estimate for compound 3 lay 1.3-fold (0.11 log units) below the measured number; the range from low to high includes it.
By their numbers in this assay, from the lowest: compound 1; then compounds 2 and 3 (each within the scatter of the next).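

In this assay, the place on a saturated chain carbon bound to an aromatic nitrogen is now seen without any aromatic ring, and the exchange of 2,4-difluorophenyl for ethyl gives a 1.8-fold higher number from compound 2 to compound 3 (0.26 log units; within the scatter), so at this place the ring of compound 2 cannot be told apart from a short chain. The exchange of 4-(trifluoromethyl)phenyl for ethyl gives a 4.0-fold higher number from compound 1 to compound 3 (0.61 log units; beyond the scatter), a step beyond the scatter, so only the ring of compound 1 separates from ethyl here and a ring as such does not. Among these three compounds the substituents on the ring therefore count for as much as the presence of a ring, with compound 1 alone standing apart. Nothing on hand accounts for these differences.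

Still open, as far as these compounds go, is whether a longer chain such as butyl, or a chain ending in an amine or a carboxylic acid, would stay with ethyl or move toward compound 1. Also open, from the compounds shown here alone, is whether an unsubstituted phenyl, or a phenyl carrying a single fluorine, would fall with compound 1 or with compound 2.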